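A few compounds are considered here, and "the series" means these few. Any claim that something is new, unique, unknown or untested is made for them only; others in the source may bear on it.

Notes on the series. In a functional assay on the whole organism for inhibition, with Rattus norvegicus as the target, read by paw edema, with stated times of 30 min and 1 h, at a dose of 10 mg/kg by the oral route (on this read-out lower numbers stand for less inhibition and higher numbers for more inhibition at the one dose given (going by the name of the read-out)), compound 1 `O=C1N=C(C2C(=O)c3ccccc3C2=O)CC(c2ccccc2)N1` gives 20% and compound 2 `O=C1N=C(C2C(=O)c3ccccc3C2=O)CC(c2ccc([N+](=O)[O-])cc2)N1` gives 16%. For the measured compounds named here, compound 2 stands lowest of the two numbers, with compound 1 nearest; the only measured step, a number 4 percentage points lower from compound 1 to compound 2 (within the scatter), lies within the scatter. Compound 3 `O=C1N=C(C2C(=O)c3ccccc3C2=O)CC(/C=C/c2ccccc2)N1` differs from compound 2 in that (2-phenylethenyl in place of 4-nitrophenyl on a saturated ring carbon). The measured step from compound 1 to compound 2 is the only one touching the same saturated ring carbon, and it stayed within the scatter; the expected step in this assay is therefore a number 2 percentage points higher from compound 2 to compound 3 (within the scatter), none beyond the scatter. Compound 3 is estimated at 18%, range 7% to 32%.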

Compound 3, a percentage reported as inhibition, in the whole organism at one dose (the size of the read-out at that dose, not a potency): 17%
Compound 3: the middle estimate sits 1 percentage points above what was measured; the range from low to high includes it.
By their numbers in this assay, from the lowest: compounds 2, 3 and 1 (each within the scatter of the next).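

In this assay, the change from an aryl group directly on the saturated ring carbon to 2-phenylethenyl gives a number 1 percentage points higher from compound 2 to compound 3 (within the scatter), and against the unsubstituted phenyl it gives a number 3 percentage points lower from compound 1 to compound 3 (within the scatter). This carbon has now carried three different groups, including one with a double bond outside the aromatic ring, without any step beyond the scatter. Nothing at hand explains these small steps.

As far as these compounds go, it remains open whether an amine or a carboxylic acid on this carbon would give a step beyond the scatter. From the compounds shown here alone, the effect of a longer chain between this carbon and the phenyl ring also remains open.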